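A Chlorophenyl in Place of a Furan: Cytotoxicity Outlook

This account rests on a few compounds, and the source may have more. Where it says the series, first, only, none or still open, it means among the compounds named here.

Compound 2 `O=C(CSc1nnnn1-c1cccc2ccccc12)N/N=C/c1ccco1` was tested in an ADME assay on MT4 cells (Homo sapiens) for cytotoxicity, read by MTT assay; on this read-out lower numbers stand for higher toxicity in this test and higher numbers for lower toxicity in this test. In this assay compound 2 gives only a limit, > 330000 nM, not a number. Its nearest measured relative, compound 1 `O=C(CSc1nnnn1-c1cccc2ccccc12)N/N=C/c1cccs1`, carries a thiophen-2-yl group where compound 2 carries a furan-2-yl group. In this assay compound 1 also gives only a limit, > 316000 nM. Compound 1 sits at the limit of > 316000 nM in this assay, at which 1 of the 2 values shown sits. Compound 2 sits at the limit of > 330000 nM in this assay, at which 1 of the 2 values shown sits. Within the data shown here, the step that the two limits leave unreadable from compound 1 to compound 2 therefore has no readable size, and nothing measured so far tells how large a change at this position can be.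

Compound 3 `O=C(CSc1nnnn1-c1cccc2ccccc12)N/N=C/c1ccc(Cl)cc1` differs from compound 2 by one change: 4-chlorophenyl in place of furan-2-yl on a carbon with a double bond to nitrogen. Among the measured compounds shown here, no measured step bears on this change, so no shift beyond the usual scatter is assumed. Compound 3 is expected to give 300000 nM in this assay, within a range from 80000 nM to 1000000 nM. That expectation corresponds to an estimated step of an at least 1.1-fold lower number from compound 2 to compound 3 (0.04 log units; that floor lies within the scatter), most likely reported again only as a limit.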

Compound 3, half-maximal cytotoxic concentration: > 295000 nM
Compound 3: no number, only a limit (the forecaster's own chance of this, stated with the estimate: 70%); the middle value lies beyond the limit too.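

Compound 1, compound 2 and compound 3 all give only limits in this assay, so neither step to compound 3 can be read. The compounds shown leave open at what concentration each becomes toxic, and whether changing this group shifts that concentration at all.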